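The source may report more compounds than this note shows. Statements on the series, on what has been measured and on what is new or still open speak of the compounds shown alone.

Working notes on the series, read in a functional assay on HepG2 cells (Homo sapiens) for inhibition, read by MTT assay, with a stated time of 24 h; on this read-out lower numbers stand for stronger inhibition and higher numbers for weaker inhibition. Among the measured compounds shown here, compound 1 (`CC1(C)[C@H]2CC[C@]1(C)N(Cc1cn(-c3ccccc3)nn1)C(=O)C2`) gives 90 nM and compound 2 (`Cc1ccc(-n2cc(CN3C(=O)C[C@@H]4CC[C@@]3(C)C4(C)C)nn2)cc1`) gives 480 nM, the higher of the two numbers measured so far. Compound 3 (`CC1(C)[C@H]2CC[C@]1(C)N(Cc1cn(-c3ccccc3O)nn1)C(=O)C2`) is next. Its change from compound 2 is 2-hydroxyphenyl in place of 4-methylphenyl on an aromatic nitrogen of the five-membered aromatic ring with 3 nitrogen.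

For the measured compounds named here, one measured step bears on this: a 5.3-fold higher number from compound 1 to compound 2 (0.73 log units; beyond the scatter), a modest step beyond the scatter, for methyl in place of hydrogen on an aromatic carbon. Compound 3 loses that methyl, so compound 1 at 90 nM is the closest reference and points to a lower number. Going by the values given here, no measured compound carries 2-hydroxyphenyl, so that part of the change has no measured step behind it, and the range must stay wide. A modest step in this assay towards lower numbers is expected, somewhat smaller than the measured one.

The expected step is a 2.4-fold lower number from compound 2 to compound 3 (0.38 log units; beyond the scatter). Compound 3 is estimated at 200 nM, with an expected range of 50 nM to 800 nM.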

Compound 3, half-maximal inhibitory concentration: 120 nM
Compound 3: middle estimate off by 1.7-fold (0.22 log units), on the high side; measured number inside the range.
By their numbers in this assay, from the lowest: compounds 1 and 3 (each within the scatter of the next); then compound 2.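

In this assay, 2-hydroxyphenyl in place of 4-methylphenyl on the aromatic nitrogen gives a 4.0-fold lower number from compound 2 to compound 3 (0.60 log units; beyond the scatter), so the number measured for compound 2 is not the level for every substituted phenyl at this position. Adding a hydroxy group to the phenyl ring gives a 1.3-fold higher number from compound 1 to compound 3 (0.12 log units; within the scatter), within the scatter, so this phenyl ring can carry a substituent with no change beyond the scatter, whereas the only earlier substituent step, methyl in place of hydrogen, was a 5.3-fold higher number from compound 1 to compound 2 (0.73 log units; beyond the scatter). Nothing available explains why the two substituted compounds differ in this way.

The step from compound 2 to compound 3 changes both the group and its place on the phenyl ring, so the compounds shown do not tell whether the group, its place or both account for it. From the compounds shown here alone, whether 2-methylphenyl would track compound 2 or compound 3, whether 4-hydroxyphenyl would stay level with compound 1, and how an amine or a carboxylic acid on this ring would read remain open.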